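A few compounds are considered here, and "the series" means these few. Any claim that something is new, unique, unknown or untested is made for them only; others in the source may bear on it.

Series notes. Compound 1 `CCN(CC)CCNC(=O)c1ccc(C(CC)(CC)c2ccc(OCS(=O)(=O)c3ccccc3)c(C)c2)n1CC` gives 4680 nM in a functional assay on MCF7 cells (Homo sapiens) for antiproliferative activity, read by MTT assay, with a stated time of 24 h; on this read-out higher numbers stand for weaker inhibition and lower numbers for stronger inhibition. Compound 2 `CCN(CC)CCNC(=O)c1ccc(C(CC)(CC)c2ccc(OCS(C)(=O)=O)c(C)c2)n1CC` gives 14700 nM. The change from compound 2 to compound 1 is phenyl in place of methyl on a sulfonyl sulfur and gave a 3.1-fold lower number from compound 2 to compound 1 (0.50 log units; beyond the scatter). Compound 3 `CCN(CC)CCNC(=O)c1cc(C(CC)(CC)c2ccc(OCSC)c(C)c2)cn1CC` gives 4640 nM, a number that sits within the scatter of compound 1; how the core of compound 3 differs from that of compound 2 is not broken down here.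

Compound 4 `CCN(CC)CCNC(=O)c1cc(C(CC)(CC)c2ccc(OCSc3ccccc3)c(C)c2)cn1CC` is not yet measured. Relative to compound 3 it carries phenyl in place of methyl on a sulfur. This is the same kind of change as that from compound 2 to compound 1, not the same: there the place was a sulfonyl sulfur, here a sulfur whose other neighbours are a saturated chain carbon. Because compound 2 to compound 1 gave a 3.1-fold lower number from compound 2 to compound 1 (0.50 log units; beyond the scatter), a step of similar direction but smaller size, a 2.0-fold lower number from compound 3 to compound 4 (0.30 log units; within the scatter), is expected for compound 4, with one precedent only. Compound 4 is estimated at 2300 nM, with a range from 900 nM to 6000 nM.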

Compound 4, half-maximal inhibitory concentration: 4700 nM
Compound 4: middle estimate off by 2.0-fold (0.31 log units), on the low side; the range from low to high includes it.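

In this assay, phenyl in place of methyl on a sulfur gives a 1.0-fold higher number from compound 3 to compound 4 (0.01 log units; within the scatter), so the drop in the number seen on the sulfonyl pair does not carry over to this pair. The two steps differ: the same change on two cores in this assay, a 3.1-fold lower number (0.50 log units; beyond the scatter) from compound 2 to compound 1 and a 1.0-fold higher number (0.01 log units; within the scatter) from compound 3 to compound 4, 3.2-fold (0.50 log units) apart, beyond the scatter of two such steps

The two pairs differ both at the sulfur and in the rest of the core, and these data do not separate the two differences or support a rule for any other core.

Still open, as far as these compounds go, is what a sulfonyl sulfur bearing methyl or phenyl would give on the core of compound 3. Also open, from the compounds shown here alone, is whether an ethyl group or a longer chain on the sulfur, or an amine on the phenyl ring, would change the number on either core.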